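A Second Fluoro on the Anilide Ring of Compound 1

The source may hold more compounds than are shown below. What is called first, only, known or untested is meant among the compounds shown, and "the series" means these compounds.

Compound 1 `CN1C[C@H](C(=O)Nc2ccc(F)cc2)[C@@H](c2ccc(/C=C/C(=O)Nc3ccccc3N)cc2)C1` sits lowest among the three measured compounds in an in vitro ADME assay on microsomes from liver (Homo sapiens) for pharmacokinetics, read by LC-MS, with a stated time of 10 min, tested at 1 uM (a lower number here means slower removal, a higher number faster removal of the compound), where compound 1 gives 5 mL/min/kg. Compound 2 `CN1C[C@H](C(=O)Nc2ccc(C(F)(F)F)cc2)[C@@H](c2ccc(/C=C/C(=O)Nc3ccccc3N)cc2)C1` gives 6 mL/min/kg and compound 3 `Cc1cc(NC(=O)[C@H]2CN(C)C[C@@H]2c2ccc(/C=C/C(=O)Nc3ccccc3N)cc2)ccc1F` gives 15 mL/min/kg in this assay. The step of a 1.2-fold higher number from compound 1 to compound 2 (0.08 log units; within the scatter) did not move the number beyond the scatter, whereas a 3.0-fold higher number from compound 1 to compound 3 (0.48 log units; beyond the scatter) and a 2.5-fold higher number from compound 2 to compound 3 (0.40 log units; beyond the scatter) were modest rises.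

Compound 4 `CN1C[C@H](C(=O)Nc2ccc(F)cc2F)[C@@H](c2ccc(/C=C/C(=O)Nc3ccccc3N)cc2)C1` differs from compound 1 by fluoro in place of hydrogen on an aromatic carbon, taking 4-fluorophenyl to 2,4-difluorophenyl. Going by the values given here, no measured step changes exactly this position, so the bearing steps are indirect: the fluoro-to-trifluoromethyl change stayed within the scatter, while adding a methyl on the same ring raised the number modestly. Since a single fluoro entering an aromatic carbon is a smaller addition than a methyl, compound 4 is expected to stay close to compound 1, with at most a slight rise, as a 1.2-fold higher number from compound 1 to compound 4 (0.08 log units; within the scatter). Compound 4 is therefore estimated at 6 mL/min/kg in this assay, within a range of 3 mL/min/kg to 12 mL/min/kg.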

Compound 4, clearance: 12 mL/min/kg
Beside the measured number, compound 4's estimate is 2.0-fold (0.30 log units) below it, and the stated range covers the measured number.
By their numbers in this assay, from the lowest: compounds 1, 2, 4 and 3 (each within the scatter of the next, the first and the last beyond it).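

In this assay, fluoro in place of hydrogen on the aromatic carbon ortho to a large group gives a 2.4-fold higher number from compound 1 to compound 4 (0.38 log units; beyond the scatter), so even a single added fluorine on this ring moves the number beyond the scatter, unlike the exchange of fluoro for trifluoromethyl in a 1.2-fold higher number from compound 1 to compound 2 (0.08 log units; within the scatter). The result also places compound 4 near the methyl-bearing compound 3, with a 1.3-fold lower number from compound 3 to compound 4 (0.10 log units; within the scatter), while the gap to the trifluoromethyl analogue is a 2.0-fold higher number from compound 2 to compound 4 (0.30 log units; within the scatter), so neither of these two steps separates the compounds beyond the scatter. No evidence is available here that would explain the rise at this position.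

As far as these compounds go, it remains open whether the rise belongs to this particular carbon or would follow a second group anywhere on the ring. Also open, from the compounds shown here alone, is how a chloro, methoxy or amino group would read on the same carbon.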